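A Dimethylamino Swap Against a Flat Cytotoxicity Ceiling

This account rests on a few compounds, and the source may have more. Where it says the series, first, only, none or still open, it means among the compounds named here.

Compound 2 `Cc1ccccc1-c1nn(-c2ccc(F)cc2F)cc1CNCCN1CCN(C)CC1` is the starting point here. In an ADME assay on Huh-7 cells (Homo sapiens) for cytotoxicity (a higher number here means that more compound is tolerated, a lower number that less compound is tolerated), compound 2 gives > 20000 nM, which is a limit of the assay and not a number. Compound 1 `Cc1ccccc1-c1nn(Cc2ccc(F)cc2)cc1CNCCN1CCN(C)CC1` gives > 20000 nM in this assay, again a limit. Compound 3 `CCOC(=O)Cn1cc(CNCCN2CCN(C)CC2)c(-c2ccccc2C)n1` gives > 20000 nM in this assay, also a limit. The three measured steps, a step that the two limits leave unreadable from compound 1 to compound 2, a step that the two limits leave unreadable from compound 1 to compound 3 and a step that the two limits leave unreadable from compound 2 to compound 3, cannot be sized because of the limit of > 20000 nM in this assay, at which 3 of the 3 values shown sit. Every change recorded so far sits on the ring nitrogen of the shared core or on the chain attached to it; none touches the 2-methylphenyl group.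

Compound 4 `CN1CCN(CCNCc2cn(-c3ccc(F)cc3F)nc2-c2cccc(N(C)C)c2)CC1` is the next compound. Relative to compound 2 it carries 3-(dimethylamino)phenyl in place of 2-methylphenyl on an aromatic carbon. Among the compounds with values here, no measured step bears on this position, so the prior evidence offers only the observation that three varied compounds all sit at the same limit in this assay. The step from compound 2 to compound 4 in this assay is therefore expected to be a step that the limit leaves unreadable from compound 2 to compound 4, with compound 4 most likely remaining at the limit. Compound 4 is estimated at 25000 nM in this assay, within a range from 8000 nM to 60000 nM.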

Compound 4, half-maximal cytotoxic concentration: > 20000 nM
Compound 4 gave a limit, no number (the forecaster's own chance of this, stated with the estimate: 70%); the middle value lies beyond the limit too.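

In this assay compound 4 gives > 20000 nM, which is a limit of the assay and not a number, so the step from compound 2 to compound 4 cannot be read: the limit of > 20000 nM in this assay, at which 4 of the 4 values shown sit.

The compounds shown leave open where any of the four truly stands in this assay, and whether 3-(dimethylamino)phenyl in place of 2-methylphenyl changes the tolerated concentration at all.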